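A few compounds are considered here, and "the series" means these few. Any claim that something is new, unique, unknown or untested is made for them only; others in the source may bear on it.

Measured in a functional assay on cells (T-cell line, Homo sapiens) for inhibition; on this read-out higher numbers stand for weaker inhibition and lower numbers for stronger inhibition:
- compound 1 `COc1ccc(CCCN2CCC(COCc3ccc(Cl)c(Cl)c3)CC2)cc1`: 200 nM
- compound 2 `CN1CCC(COC(c2ccccc2)c2ccccc2)CC1`: > 20000 nM

Compound 2 stands at > 20000 nM in this assay, and this is a limit of the assay, not a number. Its true position is therefore unknown.

The next compound is compound 3 `Clc1ccccc1CCCN1CCC(COC(c2ccccc2)c2ccccc2)CC1`. The change is 2-(2-chlorophenyl)ethyl in place of hydrogen on a saturated chain carbon bound to an amine nitrogen in a ring. Cut one bond further out, the same change reads methyl to 3-(2-chlorophenyl)propyl.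

Within the data shown here, the two measured compounds differ in more than one place, so no measured step gauges this change directly. Among the measured compounds shown here, the only numerical anchor is compound 1, which also has an aryl-ended propyl chain on the ring amine nitrogen and gives 200 nM. On that basis, a large move towards stronger inhibition, well beyond the scatter, is expected, and the expected step is an at least 33-fold lower number from compound 2 to compound 3 (1.52 log units; beyond the scatter). This size remains uncertain, given the limit on one side.

For compound 3 the estimated value in this assay is 600 nM, with an expected range of 100 nM to 4000 nM.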

Compound 3, half-maximal inhibitory concentration: 800 nM
For compound 3 the middle estimate is 1.3-fold (0.12 log units) below the measured one; the measured number falls inside the stated range.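

Among these compounds, this is the first comparison that differs in one place only, and it shows that the position on a saturated chain carbon bound to an amine nitrogen in a ring strongly affects the read-out. In this assay, methyl to 3-(2-chlorophenyl)propyl gives an at least 25-fold lower number from compound 2 to compound 3 (1.39 log units; beyond the scatter), so with the rest of the structure shared, this one change moves the series from no measurable number to a measured value. The value of compound 2 is a limit and not a number, so the step has a lower bound only and its full size cannot be read: the limit of > 20000 nM in this assay, at which 1 of the 3 values shown sits.

The compounds shown do not separate the contribution of the longer chain from that of the 2-chlorophenyl end, so a plain propyl chain, a 3-phenylpropyl group without the chlorine and a longer chain ending in 2-chlorophenyl would each address a different part of this step. Also open, on these data alone, is whether the aryl end is needed at all, which a chain ending in a carboxylic acid or an amine in its place would test, and how the chlorine behaves relative to a methoxy group on the same ring.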